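This account rests on a few compounds, and the source may have more. Where it says the series, first, only, none or still open, it means among the compounds named here.

Compound 1 `COc1ccc(C(=O)CSc2nc(Cc3c(Cl)cccc3Cl)cc(=O)[nH]2)cc1`: > 11000 nM
Compound 2 `COc1ccc(C(=O)CSc2nc(Cc3c(F)cccc3Cl)cc(=O)[nH]2)cc1`: > 12000 nM
Compound 3 `Cc1c(Cc2c(F)cccc2Cl)nc(SCC(=O)c2ccccc2)[nH]c1=O`: > 12000 nM

These three values come from an ADME assay on MT4 cells (Homo sapiens) for cytotoxicity, read by MTT assay; a higher number here means that more compound is tolerated, a lower number that less compound is tolerated. The value of compound 1 is a limit of this assay, not a number. The value of compound 2 is likewise a limit. The value of compound 3 is also a limit. The change from compound 1 to compound 2 is fluoro in place of chloro on an aromatic carbon, and it makes a step that the two limits leave unreadable from compound 1 to compound 2. What can be said rests on the limit of > 11000 nM in this assay, at which 1 of the 3 values shown sits, and on (the limit of > 12000 nM in this assay, at which 2 of the 3 values shown sit).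

Compound 4 `Cc1c(Cc2c(F)cccc2F)nc(SCC(=O)c2ccccc2)[nH]c1=O` has not yet been measured. It differs from compound 3 by fluoro in place of chloro on an aromatic carbon. Going by the values given here, this is the same kind of change as the one from compound 1 to compound 2, though here the place is meta to a fluoro group, whereas there it was meta to a chloro group. How the core of compound 3 differs from the core of compound 1 is not broken down here.

Compound 3 sits at a limit, > 12000 nM. Among the compounds with values here, the step expected from compound 3 to compound 4 is a number no higher from compound 3 to compound 4 (the limit leaves the size open), that is, essentially no step, since the same kind of change left compound 1 and compound 2 both at a limit. Compound 4 is therefore estimated at 12000 nM in this assay, between 7000 nM and 30000 nM, with a good chance that only a limit is again reported.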

Compound 4, half-maximal cytotoxic concentration: 65000 nM
Estimate against measurement, compound 4: 5.4-fold (0.73 log units) below; measured number outside the range, above it.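

Compound 3 gives > 12000 nM in this assay and this is a limit, not a number. The step to compound 4 therefore cannot be read. From the compounds shown here alone, the size of the effect of fluoro in place of chloro in this assay stays open, with neither pair showing this change, compound 1 with compound 2 or compound 3 with compound 4, giving two plain numbers.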